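Same Sulfur Change Applied to a Trihydroxyphenyl Core

The compounds below may be only part of what the source reports. "The series", "measured", "known", "first", "only" and "open" are said of these compounds alone.

Compound 1 `Cc1ccc(S/C(=C/c2ccc(Br)cc2)C(=O)c2ccc(Cl)cc2)cc1` gives 25000 nM. Compound 2 `O=C(/C(=C\c1ccc(Br)cc1)SCc1ccc(Cl)cc1)c1ccc(Cl)cc1` gives 1000 nM. Compound 3 `O=C(/C(=C\c1c(O)cc(O)cc1O)SCc1ccc(Cl)cc1)c1ccc(Cl)cc1` gives > 100000 nM, which is a limit of the assay and not a number.

These values come from a functional assay on DU-145 cells (Homo sapiens) for inhibition, read by trypan blue exclusion, with a stated time of 96 h; on this read-out higher numbers stand for weaker inhibition of growth and lower numbers for stronger inhibition of growth. Compound 2 and compound 1 differ by 4-methylphenyl in place of 4-chlorobenzyl on a sulfur, and this change made a 25-fold higher number from compound 2 to compound 1 (1.40 log units; beyond the scatter). The two cores differ by 2,4,6-trihydroxyphenyl in place of 4-bromophenyl on a double-bonded chain carbon bound to a double-bonded chain carbon, which made an at least 100-fold higher number from compound 2 to compound 3 (2.00 log units; beyond the scatter); compound 3 sits at the limit of > 100000 nM in this assay, at which 1 of the 3 values shown sits. Compound 4 `Cc1ccc(S/C(=C/c2c(O)cc(O)cc2O)C(=O)c2ccc(Cl)cc2)cc1` has not been measured; it differs from compound 3 by 4-methylphenyl in place of 4-chlorobenzyl on a sulfur, the same change at the same place. The step is expected to be a step that the limit leaves unreadable from compound 3 to compound 4 because the same change gave a 25-fold higher number from compound 2 to compound 1 (1.40 log units; beyond the scatter). Compound 4 is therefore expected near 500000 nM, between 100000 nM and 3000000 nM, and most likely this assay will again report only a limit.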

Compound 4, concentration for 50% growth inhibition: > 100000 nM
Compound 4: a limit, no number (the forecaster's own chance of this, stated with the estimate: 90%); the middle value lies beyond the limit too.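

In this assay the 2,4,6-trihydroxyphenyl group in place of 4-bromophenyl gave an at least 4.0-fold higher number from compound 1 to compound 4 (0.60 log units; beyond the scatter) and not only the earlier step on the 4-chlorobenzyl core, so growth inhibition became weaker on both cores. This shows the same direction twice, but not that the size carries over from one core to the other: the same change on two cores in this assay, an at least 100-fold higher number (2.00 log units; beyond the scatter) from compound 2 to compound 3 and an at least 4.0-fold higher number (0.60 log units; beyond the scatter) from compound 1 to compound 4; the limit leaves it open whether they differ. The step from 4-chlorobenzyl to 4-methylphenyl on a sulfur, from compound 3 to compound 4, cannot be read, since both compounds sit at a limit of the assay and not at a number: the limit of > 100000 nM in this assay, at which 2 of the 4 values shown sit.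

The compounds shown leave open whether that sulfur change has any effect on the trihydroxyphenyl core. They also leave open how an amine or a carboxylic acid on the sulfur in place of 4-methylphenyl would behave.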